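The compounds below may be only part of what the source reports. "The series", "measured", "known", "first", "only" and "open" are said of these compounds alone.

Measured compounds:
- compound 1, `Cc1cc(N2CC[C@@H](C)[C@@H](N(C)c3ncnc4[nH]ccc34)C2)n2nc(SCC3CCCCC3)nc2n1`, 9170 nM in a functional assay on MGC-803 cells (Homo sapiens) for inhibition, read by MTT assay, with a stated time of 72 h; a higher number here means a weaker inhibitor, a lower number a stronger inhibitor
- compound 2, `Cc1cc(N2CC[C@@H](C)[C@@H](N(C)c3ncnc4[nH]ccc34)C2)n2nc(SCc3ccc(C(F)(F)F)cc3)nc2n1`, 2680 nM
- compound 3, `C=CCSc1nc2nc(C)cc(N3CC[C@@H](C)[C@@H](N(C)c4ncnc5[nH]ccc45)C3)n2n1`, 32600 nM

All three share one core and differ only in the group carried on a saturated chain carbon bound to a sulfur. Compound 3 gives the highest number of the three, so it is the weakest inhibitor here: the step of a 3.6-fold higher number from compound 1 to compound 3 (0.55 log units; beyond the scatter) is modest, and the step of a 12-fold higher number from compound 2 to compound 3 (1.09 log units; beyond the scatter) is large.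

Compound 4, `Cc1cc(N2CC[C@@H](C)[C@@H](N(C)c3ncnc4[nH]ccc34)C2)n2nc(SCCc3ccccc3)nc2n1`, has not yet been measured. Its change from compound 3 is benzyl in place of vinyl on a saturated chain carbon bound to a sulfur. Among the measured compounds shown here, two measured steps bear on this: a 12-fold higher number from compound 2 to compound 3 (1.09 log units; beyond the scatter) shows that replacing an aromatic ring by vinyl raised the number strongly, and a 3.6-fold higher number from compound 1 to compound 3 (0.55 log units; beyond the scatter) shows that replacing a saturated ring by vinyl raised it moderately. Compound 4 restores an aromatic ring, without the trifluoromethyl of compound 2 and one carbon further out, so the number is expected to fall by an amount between those two steps. The step of a 5.9-fold lower number from compound 3 to compound 4 (0.77 log units; beyond the scatter) is therefore the expected outcome. Compound 4 is estimated at 5500 nM, with a likely range from 2000 nM to 15000 nM.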

Compound 4, half-maximal inhibitory concentration: 6190 nM
Compound 4: middle estimate off by 1.1-fold (0.05 log units), on the low side, and the stated range covers the measured number.
By their numbers in this assay, from the lowest: compound 2; then compounds 4 and 1 (each within the scatter of the next); then compound 3.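

In this assay, going from allyl to phenethyl (a 5.3-fold lower number from compound 3 to compound 4 (0.72 log units; beyond the scatter)) shows that a plain aromatic ring on this saturated chain carbon bound to a sulfur also gives a lower number than vinyl, without any trifluoromethyl. An aromatic ring as such gives no clear edge here, since benzyl and cyclohexyl cannot be told apart (a 1.5-fold lower number from compound 1 to compound 4 (0.17 log units; within the scatter)). Compound 2 still keeps a modest lead (a 2.3-fold higher number from compound 2 to compound 4 (0.36 log units; beyond the scatter)), but that step changes both the trifluoromethyl and the length of the chain, so the two effects cannot be separated.

Open, going by these compounds, is how a benzylsulfanyl group, which would separate them, or a chain ending in an amine or a carboxylic acid would compare. Nothing measured here explains these differences.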